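Thioether variation at the alkoxy position of the pyridine series

The compounds below may be only part of what the source reports. "The series", "measured", "known", "first", "only" and "open" are said of these compounds alone.

Compound 3 `CC(C(=O)NCc1ccc(C(C)(C)C)nc1SCCCN(C)C)c1ccc(NS(C)(=O)=O)c(F)c1` carries a (3-(dimethylamino)propyl)sulfanyl group where compound 1 `CC(C)Oc1nc(C(C)(C)C)ccc1CNC(=O)C(C)c1ccc(NS(C)(=O)=O)c(F)c1` carries an isopropoxy group and compound 2 `CCOCCOc1nc(C(C)(C)C)ccc1CNC(=O)C(C)c1ccc(NS(C)(=O)=O)c(F)c1` a 2-ethoxyethoxy group. In an assay on cells for antagonist activity at transient receptor potential cation channel subfamily V member 1 (Homo sapiens), read by FLIPR and calcium flux, with a stated time of 6 min (a lower number here means a stronger inhibitor, a higher number a weaker inhibitor), compound 1 gives 2.3 nM, compound 2 gives 23.9 nM and compound 3 gives 51.8 nM. The steps run a 10-fold higher number from compound 1 to compound 2 (1.02 log units; beyond the scatter), a 23-fold higher number from compound 1 to compound 3 (1.35 log units; beyond the scatter) and a 2.2-fold higher number from compound 2 to compound 3 (0.34 log units; beyond the scatter), so compound 3 stands at the highest number of the three, with compound 2 nearest and compound 1 furthest.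

Compound 4 `COc1ccc(CSc2nc(C(C)(C)C)ccc2CNC(=O)C(C)c2ccc(NS(C)(=O)=O)c(F)c2)cc1` differs from compound 3 by 4-methoxyphenyl in place of 2-(dimethylamino)ethyl on a saturated chain carbon bound to a sulfur. Among the compounds with values here, none of the measured steps changes the group on the sulfur-bound chain; the steps from compound 1 and compound 2 to compound 3 only show that exchanging the whole oxygen-linked group for the sulfur-linked amine chain raised the number. The present change keeps the sulfur link and swaps the amine end for an aromatic ring, which nothing in the series tests directly. The expectation for compound 4 in this assay is therefore a step of a 1.7-fold lower number from compound 3 to compound 4 (0.24 log units; within the scatter), with low confidence in its direction. Compound 4 is estimated at 30 nM, within a range of 8 nM to 120 nM.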

Compound 4, inhibition constant: 3.5 nM
Compound 4: the middle estimate sits 8.6-fold (0.93 log units) above what was measured; measured number outside the range, below it.
By their numbers in this assay, from the lowest: compounds 1 and 4 (each within the scatter of the next); then compound 2; then compound 3.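

In this assay the sulfur link does not by itself hold the number up at this position: the step is a 15-fold lower number from compound 3 to compound 4 (1.17 log units; beyond the scatter) when 4-methoxyphenyl replaces 2-(dimethylamino)ethyl on the saturated chain carbon bound to a sulfur, so what the sulfur-linked chain carries matters strongly here. The (4-methoxybenzyl)sulfanyl group also compares well with 2-ethoxyethoxy, with a 6.8-fold lower number from compound 2 to compound 4 (0.83 log units; beyond the scatter) as the step, while the step against isopropoxy, a 1.5-fold higher number from compound 1 to compound 4 (0.18 log units; within the scatter), leaves those two groups without an order, which shows that a sulfur-linked group with an aromatic ring can match the isopropoxy compound in this assay. No supporting data bear on why these changes act as they do.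

From the compounds shown here alone, the step from compound 3 to compound 4 removes a dimethylamino group and adds a methoxy-bearing aromatic ring in one change, so the share of each remains open; an unsubstituted benzylsulfanyl group or a plain propylsulfanyl chain would separate them. The effect of sulfur against oxygen also remains open, since no matched pair is shown, and isopropylsulfanyl against isopropoxy or 4-methoxybenzyloxy against (4-methoxybenzyl)sulfanyl would address it.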